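From Methoxyphenyl to Difluorophenyl on the Carbonyl Carbon

This account rests on a few compounds, and the source may have more. Where it says the series, first, only, none or still open, it means among the compounds named here.

Three compounds have been measured in a functional assay on OVCAR-3 cells (Homo sapiens) for inhibition, read by sulforhodamine B assay, with a stated time of 48 h; a higher number here means a weaker inhibitor of growth, a lower number a stronger inhibitor of growth:
compound 1, `COc1cc(-c2cc(/C=C/C(=O)c3ccc(N)cc3)[nH]n2)cc(OC)c1OC`, with 1570 nM;
compound 2, `COc1cc(-c2cc(/C=C/C(=O)c3ccc(Cl)c(Cl)c3)[nH]n2)cc(OC)c1OC`, with 6990 nM;
compound 3, `COc1ccc(C(=O)/C=C/c2cc(-c3cc(OC)c(OC)c(OC)c3)n[nH]2)cc1`, with 1740 nM.

Compound 3 has the second highest number of the three. Its nearest neighbour is compound 1, and the step of a 1.1-fold higher number from compound 1 to compound 3 (0.04 log units; within the scatter) lies within the scatter. The furthest is compound 2, and the step of a 4.0-fold lower number from compound 2 to compound 3 (0.60 log units; beyond the scatter) is modest but beyond the scatter.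

Compound 4, `COc1cc(-c2cc(/C=C/C(=O)c3ccc(F)c(F)c3)[nH]n2)cc(OC)c1OC`, has not yet been measured. It differs from compound 3 in one place: 3,4-difluorophenyl in place of 4-methoxyphenyl on a carbonyl carbon. Among the compounds with values here, two measured steps bear on this change, since both exchange the group on a carbonyl carbon. The step of a 4.5-fold higher number from compound 1 to compound 2 (0.65 log units; beyond the scatter) brought in a 3,4-dichlorophenyl and gave a modestly higher number; the step of a 4.0-fold lower number from compound 2 to compound 3 (0.60 log units; beyond the scatter) took it out again and gave a modestly lower number. Within the data shown here, no measured compound carries a 3,4-difluorophenyl, so the size of the coming step is uncertain. Compound 4 is therefore expected to give a modestly higher number in this assay, the expected step being a 2.6-fold higher number from compound 3 to compound 4 (0.41 log units; beyond the scatter). The estimate for compound 4 is 4500 nM, with a range from 1800 nM to 11000 nM.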

Compound 4, concentration for 50% growth inhibition: 2390 nM
Estimate against measurement, compound 4: 1.9-fold (0.27 log units) above, and the stated range covers the measured number.
By their numbers in this assay, from the lowest: compounds 1, 3 and 4 (each within the scatter of the next); then compound 2.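

In this assay, 3,4-difluorophenyl on the carbonyl carbon cannot be told apart from the two groups already seen to sit at the lower end, as a 1.4-fold higher number from compound 3 to compound 4 (0.14 log units; within the scatter) for the 4-methoxyphenyl and a 1.5-fold higher number from compound 1 to compound 4 (0.18 log units; within the scatter) for the 4-aminophenyl both show. The exchange of halogens does register, however: a 2.9-fold lower number from compound 2 to compound 4 (0.47 log units; beyond the scatter) shows that two halogens on the ring at this position do not by themselves bring the higher number of compound 2, which now stands alone among the four with its 3,4-dichlorophenyl. Nothing available on these compounds offers a reason for the gap between the fluorinated and chlorinated rings.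

As far as these compounds go, it remains open where a plain phenyl, a bromophenyl or a pyridyl on the carbonyl carbon would fall, and so whether the higher number belongs to chlorine alone or to the pair of chlorines. Also open, from the compounds shown here alone, is whether a carboxylic acid or a morpholine on this ring would stay within the scatter of compounds 1, 3 and 4 or move away from them.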